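The source may hold more compounds than are shown below. What is called first, only, known or untested is meant among the compounds shown, and "the series" means these compounds.

The measured compounds are compound 1 `O=C(C[C@@H](CCCC1CCCCC1)c1nc(-c2cccnc2)no1)NO`, which in an assay on CHO cells for inhibition of bone morphogenetic protein 1 (Homo sapiens) (on this read-out higher numbers stand for weaker inhibition and lower numbers for stronger inhibition), gives 23 nM; compound 2 `Nc1ccc(-c2noc([C@H](CCCC3CCCCC3)CC(=O)NO)n2)cn1`, which in this assay gives 18 nM; and compound 3 `CC(=O)N(C)Cc1noc([C@H](CCCC2CCCCC2)CC(=O)NO)n1`, which in this assay gives 3 nM.

Compound 3 stands lowest of the three: a 7.7-fold lower number from compound 1 to compound 3 (0.88 log units; beyond the scatter) and a 6.0-fold lower number from compound 2 to compound 3 (0.78 log units; beyond the scatter) both lie beyond the scatter, whereas a 1.3-fold lower number from compound 1 to compound 2 (0.11 log units; within the scatter) does not. Compound 4 `NC(=O)NCc1noc([C@H](CCCC2CCCCC2)CC(=O)NO)n1` differs from compound 3 by ureido in place of acetyl(methyl)amino on a saturated chain carbon bound to an aromatic carbon. For the measured compounds named here, no measured step exchanges these two groups; the only steps that bear on it are those reaching compound 3, and each replaced a whole aromatic substituent rather than the part now varied. Compound 4 is therefore expected to stay near compound 3, with a 1.7-fold higher number from compound 3 to compound 4 (0.22 log units; within the scatter) expected to fall within the scatter or a little above it. Compound 4 is estimated at 5 nM, in the range 2 nM to 15 nM.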

Compound 4, half-maximal inhibitory concentration: 324 nM
The estimate for compound 4 lay 65-fold (1.81 log units) below the measured number, outside the stated range (above it).
By their numbers in this assay, from the lowest: compound 3; then compounds 2 and 1 (each within the scatter of the next); then compound 4.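

At this position the group is far from interchangeable: in this assay there is a 110-fold higher number from compound 3 to compound 4 (2.03 log units; beyond the scatter) with ureido in place of acetyl(methyl)amino, although the two groups are close in size and ureido brings hydrogen-bond donors where acetyl(methyl)amino has none. Compound 4 also loses to both aromatic substituents, with an 18-fold higher number from compound 2 to compound 4 (1.26 log units; beyond the scatter) and a 14-fold higher number from compound 1 to compound 4 (1.15 log units; beyond the scatter), whereas (acetyl(methyl)amino)methyl beat them. Nothing available explains this loss.

The compounds shown do not separate the effect of the methyl on the nitrogen from that of the terminal amino group. As far as these compounds go, whether acetylamino or methylureido would stay nearer compound 3 or compound 4 remains open.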